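From 1,3-Thiazol-2-yl to Thiophen-2-yl in Cytotoxicity Testing

The compounds below may be only part of what the source reports. "The series", "measured", "known", "first", "only" and "open" are said of these compounds alone.

Measured compounds:
- Compound 1 `O=C(Nc1ccc(Cl)cc1)C1CCCN(C(=O)c2cccc(-c3nccs3)c2)C1`: 32%
- Compound 2 `CCc1cccc(NC(=O)C2CCCN(C(=O)c3cc(C(F)(F)F)cc(C(F)(F)F)c3)C2)c1`: 0%

Of the compounds shown here, two have been tested in an ADME assay on PC-3 cells (Homo sapiens) for cytotoxicity, read by WST assay, tested at 100 uM; a lower number here means less inhibition, a higher number more inhibition at the concentration tested (going by the name of the read-out). Compound 1 gives 32%, and compound 2 gives 0%. Of these two numbers compound 1 stands highest; compound 2 lies below it by a margin beyond the usual scatter. Among the compounds with values here, the two structures differ in more than one place, so no single step between them is defined, and only their two values can be compared.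

Compound 3 `O=C(Nc1ccc(Cl)cc1)C1CCCN(C(=O)c2cccc(-c3cccs3)c2)C1` is not yet measured. It differs from compound 1 in one place: thiophen-2-yl in place of 1,3-thiazol-2-yl on an aromatic carbon. Within the data shown here, the group that leaves and the group that enters are both five-membered aromatic rings of the same size, and no measured pair shows what this exchange does in this assay. On that basis the step from compound 1 to compound 3 is expected to be small, in either direction, and not beyond the scatter: a number 2 percentage points lower from compound 1 to compound 3 (within the scatter). Compound 3 is therefore estimated at 30% in this assay, within a range from 10% to 55%.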

Compound 3, a percentage reported as inhibition, at one concentration (the size of the read-out at that concentration, not a potency): 4%
Estimate against measurement, compound 3: 26 percentage points above; measured number outside the range, below it.
By their numbers in this assay, from the lowest: compounds 2 and 3 (each within the scatter of the next); then compound 1.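

Within the data shown here, the exchange of 1,3-thiazol-2-yl for thiophen-2-yl is the first single change at this place, on an aromatic carbon meta to a large group, and in this assay it gives a number 28 percentage points lower from compound 1 to compound 3 (beyond the scatter). This shows that the place is not indifferent to which five-membered aromatic ring it carries, even though both rings have the same number of heavy atoms and neither has a hydrogen-bond donor or a net charge; what the counts separate is one nitrogen in the leaving ring where the entering ring has carbon, and one hydrogen-bond acceptor fewer in the entering ring. Nothing available explains why the number moves with this exchange.

The compounds shown leave open whether an oxazol-2-yl ring, a furan-2-yl ring or a pyridine ring at this place would give a number nearer that of compound 1 or that of compound 3. They also leave open whether the step would hold with an amine or a carboxylic acid elsewhere on the shared core, since it rests on this one pair.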